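A few compounds are considered here, and "the series" means these few. Any claim that something is new, unique, unknown or untested is made for them only; others in the source may bear on it.

Of the compounds shown here, two of the shared core have been measured so far. Compound 1 `FC1(Cc2ccccc2)CCN(CCCc2c[nH]c3ccc(-n4cnnc4)cc23)CC1` gives 0.9 nM in an assay on CHO cells for displacement of a labelled ligand from 5-hydroxytryptamine receptor 1D (Homo sapiens); a lower number here means a stronger inhibitor, a higher number a weaker inhibitor. For the measured compounds named here, compound 2 `FC1(Cc2ccccc2C(F)(F)F)CCN(CCCc2c[nH]c3ccc(-n4cnnc4)cc23)CC1` gives 0.3 nM in this assay, and the only recorded step is a 3.0-fold lower number from compound 1 to compound 2 (0.48 log units; beyond the scatter). Compound 2 therefore holds the lowest of the two numbers, with compound 1 sitting one step above it.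

Compound 3 `FC1(CCc2ccccc2)CCN(CCCc2c[nH]c3ccc(-n4cnnc4)cc23)CC1` differs from compound 2 by benzyl in place of 2-(trifluoromethyl)phenyl on a saturated chain carbon bound to a saturated ring carbon; the same difference, cut one bond further out, reads 2-(trifluoromethyl)benzyl to phenethyl. Going by the values given here, only the step from compound 1 to compound 2 bears on this change, and it ran the opposite way, trifluoromethyl coming in rather than leaving. Among the compounds with values here, the benzyl-to-phenethyl part of the change has no measured counterpart. Reversing that one modest step is the expectation here, so compound 3 is estimated at about 1 nM, with a range of 0.3 nM to 3 nM, which means an expected 3.3-fold higher number from compound 2 to compound 3 (0.52 log units; beyond the scatter) in this assay.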

Compound 3, half-maximal inhibitory concentration: 2 nM
The estimate for compound 3 lay 2.0-fold (0.30 log units) below the measured number, and the stated range covers the measured number.
By their numbers in this assay, from the lowest: compound 2; then compound 1; then compound 3.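

Extending the side chain from benzyl to phenethyl is the first change at this position to alter the chain rather than the aromatic ring, and in this assay the step of a 2.2-fold higher number from compound 1 to compound 3 (0.35 log units; beyond the scatter) is modest but beyond the scatter. The step of a 6.7-fold higher number from compound 2 to compound 3 (0.82 log units; beyond the scatter) is also modest, though it combines loss of the trifluoromethyl group with the longer chain, so it cannot apportion the shift between those two features; the step from compound 1 isolates the chain change. No measurement available here accounts for either shift.

From the compounds shown here alone, whether 2-(trifluoromethyl)phenethyl would recover the lower number seen with the trifluoromethyl group on the shorter chain remains open. Also open, going by these compounds, is how a longer chain, such as 3-phenylpropyl, or a nitrile in place of trifluoromethyl would read at this position.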